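The source may report more compounds than this note shows. Statements on the series, on what has been measured and on what is new or still open speak of the compounds shown alone.

The study concerns four spirocyclic compounds built on closely related cores and tested in an ADME assay on L02 cells (Homo sapiens) for antiproliferative activity, read by MTT assay, with a stated time of 48 h; a higher number here means a weaker inhibitor, a lower number a stronger inhibitor. Compound 1 `CCOc1ccccc1-n1nncc1CN1C(=O)C2(C(C#N)=C(N)Oc3c2c2nc4ccccc4nc2c2ccccc32)c2ccccc21` carries a 2-ethoxyphenyl on an aromatic nitrogen. In this assay compound 1 gives > 50000 nM, which is a limit of the assay and not a number. Compound 2 `N#CC1=C(N)Oc2c(c3nc4ccccc4nc3c3ccccc23)C12C(=O)N(Cc1cnnn1-c1ccc([N+](=O)[O-])cc1)c1ccccc12` differs from compound 1 only by 4-nitrophenyl in place of 2-ethoxyphenyl on an aromatic nitrogen. In this assay compound 2 gives > 50000 nM, again a limit. The step that the two limits leave unreadable from compound 1 to compound 2 therefore cannot be read in size, since both values sit at the limit.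

Compound 3 `CCOc1ccccc1-n1nncc1CN1C(=O)C2(C(C#N)=C(N)Oc3c(N)cc4nc5ccccc5nc4c32)c2ccccc21` keeps the 2-ethoxyphenyl of compound 1 but differs from it in its core; the difference between the two cores is not broken down here. In this assay compound 3 gives > 50000 nM, once more a limit. Taken together, the limit of > 50000 nM in this assay, at which 3 of the 3 values shown sit, describes the whole measured set.

Compound 4 `N#CC1=C(N)Oc2c(N)cc3nc4ccccc4nc3c2C12C(=O)N(Cc1cnnn1-c1ccc([N+](=O)[O-])cc1)c1ccccc12` has not yet been tested. It stands to compound 3 as compound 2 stands to compound 1, by 4-nitrophenyl in place of 2-ethoxyphenyl on an aromatic nitrogen, the same change made at the same place. Because the limit of > 50000 nM in this assay, at which 3 of the 3 values shown sit, shows every measured compound, including compound 3 with > 50000 nM, at the limit, the step is expected to be unreadable, and a step that the limit leaves unreadable from compound 3 to compound 4 is the estimated step. Compound 4 is therefore expected to give about 80000 nM in this assay, most likely reported only as a limit, with a range from 40000 nM to 200000 nM.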

Compound 4, half-maximal inhibitory concentration: > 50000 nM
Compound 4: only a limit was reported (the forecaster's own chance of this, stated with the estimate: 85%); the middle value lies beyond the limit too.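

In this assay compound 4 gives > 50000 nM, which is a limit of the assay and not a number. Among the compounds shown here, the change from compound 3 to compound 4 cannot be read in size, so no new step follows. The whole set stands at one limit: the limit of > 50000 nM in this assay, at which 4 of the 4 values shown sit. The compounds shown leave open how far any of them lies beyond that limit, and whether 4-nitrophenyl in place of 2-ethoxyphenyl changes the read-out at all.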